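Spiro series: aryl exchange on the aromatic nitrogen

The compounds below may be only part of what the source reports. "The series", "measured", "known", "first", "only" and "open" are said of these compounds alone.

Three members of this series have been run in a functional assay on HepG2 cells (Homo sapiens) for antiproliferative activity, read by MTT assay, with a stated time of 48 h; a higher number here means a weaker inhibitor, a lower number a stronger inhibitor. Compound 1 `N#CC1=C(N)Oc2c(c3nc4ccccc4nc3c3ccccc23)C12C(=O)N(Cc1cnnn1-c1ccc([N+](=O)[O-])cc1)c1ccccc12` carries 4-nitrophenyl on an aromatic nitrogen; in this assay compound 1 reaches only the limit > 50000 nM. Compound 2 `Cc1ccc(-n2nncc2CN2C(=O)C3(C(C#N)=C(N)Oc4c3c3nc5ccccc5nc3c3ccccc43)c3ccccc32)cc1Cl` carries 3-chloro-4-methylphenyl in the same position, and compound 2 likewise sits at the limit > 50000 nM. Compound 3 `COc1ccccc1-n1nncc1CN1C(=O)C2(C(C#N)=C(N)Oc3c(N)cc4nc5ccccc5nc4c32)c2ccccc21` carries 2-methoxyphenyl on an aromatic nitrogen, and in this assay compound 3 gives only the limit > 50000 nM. Among the compounds with values here, the single pairwise step between measured compounds is a step that the two limits leave unreadable from compound 1 to compound 2, so no size can be read from it. Within the data shown here, every value so far sits on (the limit of > 50000 nM in this assay, at which 3 of the 3 values shown sit); nothing places any compound at a numerical value.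

Compound 4 `N#CC1=C(N)Oc2c(N)cc3nc4ccccc4nc3c2C12C(=O)N(Cc1cnnn1-c1ccc(F)c(Cl)c1)c1ccccc12` is the next entry. Relative to compound 3 the change is 3-chloro-4-fluorophenyl in place of 2-methoxyphenyl on an aromatic nitrogen. Among the measured compounds shown here, the only step that bears on the same position, a step that the two limits leave unreadable from compound 1 to compound 2, is not readable and gives no direction. With all three values at the limit, the step that the limit leaves unreadable from compound 3 to compound 4 is expected to stay within the scatter. Compound 4 is therefore estimated at 60000 nM, with a range from 20000 nM to 150000 nM, and most probably is reported again as a limit rather than a number.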

Compound 4, half-maximal inhibitory concentration: > 50000 nM
Compound 4: a limit, no number; the forecaster's own chance of this, stated with the estimate: 80%; the middle value is on the limit's open side.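

Compound 3 and compound 4 are both limits in this assay, and the exchange of 2-methoxyphenyl for 3-chloro-4-fluorophenyl on an aromatic nitrogen gives no readable step. The compounds shown leave open whether any aryl exchange at this position changes antiproliferative activity, because no member has a numerical value: the limit of > 50000 nM in this assay, at which 4 of the 4 values shown sit.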